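Replacing the methoxyethylsulfanyl arm of compound 2 with butyl

The compounds below may be only part of what the source reports. "The series", "measured", "known", "first", "only" and "open" are said of these compounds alone.

Measured compounds:
compound 1 `CC1(Cc2ccccc2)C(=O)N(c2ccccc2)c2ncccc21` — 0%
compound 2 `COCCSC1(C)C(=O)N(c2ccccc2)c2ncccc21` — 23%

In a functional assay on the whole organism (Pleural cavity) for inhibition, with Rattus norvegicus as the target, at a dose of 25 mg/kg (on this read-out lower numbers stand for less inhibition and higher numbers for more inhibition at the one dose given (going by the name of the read-out)), compound 2 stands highest of the two numbers; its nearest neighbour is compound 1, and the step of a number 23 percentage points higher from compound 1 to compound 2 (beyond the scatter) is modest but beyond the scatter.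

Compound 3 `CCCCC1(C)C(=O)N(c2ccccc2)c2ncccc21` differs from compound 2 by butyl in place of (2-methoxyethyl)sulfanyl on a saturated ring carbon. Within the data shown here, the only measured step that touches this position is the one from compound 1 to compound 2, where benzyl gave way to (2-methoxyethyl)sulfanyl. Among the measured compounds shown here, no measured pair compares butyl with that chain directly, so the size of the new step is poorly anchored. The butyl group carries no hydrogen-bond acceptors and no sulfur, and in that respect stands closer to the benzyl of compound 1 than to the chain of compound 2.

Compound 3 is therefore expected to fall below compound 2 by a number 13 percentage points lower from compound 2 to compound 3 (beyond the scatter), landing between compound 1 and compound 2. The estimate for compound 3 is 10%, with a range from -5% to 28%.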

Compound 3, a percentage reported as inhibition, in the whole organism at one dose (the size of the read-out at that dose, not a potency): 5%
Compound 3: middle estimate off by 5 percentage points, on the high side, and the stated range covers the measured number.
By their numbers in this assay, from the lowest: compounds 1 and 3 (each within the scatter of the next); then compound 2.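

In this assay, among these compounds, replacing the (2-methoxyethyl)sulfanyl arm with butyl on the saturated ring carbon gives a number 18 percentage points lower from compound 2 to compound 3 (beyond the scatter), the first direct comparison of this arm with an all-carbon chain at this position. Butyl and benzyl are not distinguished here, with a number 5 percentage points higher from compound 1 to compound 3 (within the scatter), so among the three groups shown only the (2-methoxyethyl)sulfanyl arm stands apart. Nothing available accounts for this difference.

The compounds shown do not separate the contribution of the sulfur from that of the ether oxygen, since both leave together in the change to butyl. As far as these compounds go, a butylsulfanyl arm, which holds the sulfur without the oxygen, and a 3-methoxypropyl arm, which holds the oxygen without the sulfur, remain open comparisons at this position.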